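Methylation of the ring nitrogen in a kinase series

The compounds below may be only part of what the source reports. "The series", "measured", "known", "first", "only" and "open" are said of these compounds alone.

Compound 1 `Cc1cc2[nH]nc(N)c2c(N2CCCCC2)n1` and compound 2 `Cn1nc(N)c2c(=O)[nH]c(-c3ccccc3)cc21` were tested in an assay on isolated protein for inhibition of serine/threonine-protein kinase D2 (Homo sapiens), read by mobility shift assay, tested at 30 uM; on this read-out higher numbers stand for more inhibition at the one concentration tested (going by the name of the read-out) and lower numbers for less inhibition. Compound 1 gives 14%, and compound 2 gives 14%, so the two stand level within the scatter; compound 1 sits at a low level of inhibition among the measured compounds. Compound 3 `Cc1cc2c(c(N)nn2C)c(N2CCCCC2)n1` differs from compound 1 by methyl in place of hydrogen on an aromatic nitrogen. Going by the values given here, no step between measured compounds shows what this change does here, so the step of a number 2 percentage points lower from compound 1 to compound 3 (within the scatter) is expected to stay within the scatter in either direction. On that basis compound 3 is estimated to give 12%, with a range from 0% to 30% in this assay.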

Compound 3, a percentage reported as inhibition, at one concentration (the size of the read-out at that concentration, not a potency): 16%
Compound 3: middle estimate off by 4 percentage points, on the low side; measured number inside the range.
By their numbers in this assay, from the lowest: compounds 1, 2 and 3 (each within the scatter of the next).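

In this assay, going by these compounds alone, methyl in place of hydrogen on the aromatic nitrogen gives a number 2 percentage points higher from compound 1 to compound 3 (within the scatter) and thus a first direct reading at this position. On the core of compound 1, the hydrogen on this nitrogen can be replaced by methyl with no shift beyond the scatter, and inhibition stays low. Nothing available explains this result.

As far as these compounds go, whether an ethyl group, or a longer chain carrying an amine, would read differently on this nitrogen remains open. So does whether methyl here would matter on a compound with stronger inhibition.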